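Working notes: from compound 2 to compound 4

The source may hold more compounds than are shown below. What is called first, only, known or untested is meant among the compounds shown, and "the series" means these compounds.

Measured so far in a functional assay on 3T3-L1 cells (Mus musculus) for inhibition, with a stated time of 20 min, tested at 20 uM; on this read-out lower numbers stand for less inhibition and higher numbers for more inhibition at the one concentration tested (going by the name of the read-out):
compound 1 `O=S(=O)(c1ccc(F)cc1)N(Cc1ccccc1)Cc1cccc(F)c1F` gives -81.9%
compound 2 `COc1cc(OC)c(Cn2cc(CN(Cc3cn(S(=O)(=O)c4ccc(C)cc4)c4ccccc34)S(=O)(=O)c3ccc(C)cc3)nn2)c(OC)c1` gives -22%
compound 3 `Cc1ccc(S(=O)(=O)n2cc(CNCc3cccc(F)c3F)c3ccccc32)cc1` gives 46%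

Compound 2 stands second highest of the three numbers; compound 1 lies below it beyond the scatter, compound 3 above it beyond the scatter. Among the measured compounds shown here, no pair of measured compounds differs in one place only, so no step is known.

Compound 4 `Cc1ccc(S(=O)(=O)N(Cc2cn(Cc3ccccc3)nn2)Cc2cn(S(=O)(=O)c3ccc(C)cc3)c3ccccc23)cc1` differs from compound 2 by phenyl in place of 2,4,6-trimethoxyphenyl on a saturated chain carbon bound to an aromatic nitrogen. Nothing measured here bears on that change, so a step of no size beyond the scatter is expected in this assay.

Compound 4 is estimated at -15%, within -50% to 20%, an expected step of a number 7 percentage points higher from compound 2 to compound 4 (within the scatter).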

Compound 4, a percentage reported as inhibition, at one concentration (the size of the read-out at that concentration, not a potency): 3.4%
Compound 4: the middle estimate sits 18.4 percentage points below what was measured; low and high end bracket the measured number.
By their numbers in this assay, from the lowest: compound 1; then compound 2; then compound 4; then compound 3.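

In this assay, this position responds to the aryl group it carries: phenyl in place of 2,4,6-trimethoxyphenyl on a saturated chain carbon bound to an aromatic nitrogen gives a step of a number 25.4 percentage points higher from compound 2 to compound 4 (beyond the scatter). The three methoxy groups are therefore not required for the read-out here, and the number rises without them. No available evidence accounts for this shift.

The compounds shown leave open whether a single methoxy group on the phenyl ring would give the same step. On these data alone, how a carboxylic acid or an amine on that phenyl ring would read also remains open.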